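The source may report more compounds than this note shows. Statements on the series, on what has been measured and on what is new or still open speak of the compounds shown alone.

Compound 1 `CCO/C(O)=C1\C(COCCNC(=O)c2cccnc2)=NC(C)=C(C(=O)OC)C1c1ccccc1Cl` carries a (pyridin-3-yl)carbonyl group on the amine nitrogen of its side chain, and in a functional assay (aorta) with Rattus norvegicus as the target (on this read-out higher numbers stand for weaker inhibition and lower numbers for stronger inhibition), compound 1 gives 15.9 nM, the lowest of the three numbers recorded. Compound 2 `CCO/C(O)=C1\C(COCCNC(=O)c2cnccn2)=NC(C)=C(C(=O)OC)C1c1ccccc1Cl` gives 39.8 nM in this assay, and compound 3 `CCO/C(O)=C1\C(COCCNC(=O)NCC(N)=O)=NC(C)=C(C(=O)OC)C1c1ccccc1Cl` gives 20 nM. The two measured steps away from compound 1 went in the same direction but differed in size: a 2.5-fold higher number from compound 1 to compound 2 (0.40 log units; beyond the scatter), whereas a 1.3-fold higher number from compound 1 to compound 3 (0.10 log units; within the scatter). Compound 4 `CCO/C(O)=C1\C(COCCNS(N)(=O)=O)=NC(C)=C(C(=O)OC)C1c1ccccc1Cl` has not yet been measured. It differs from compound 1 in one place: sulfamoyl in place of (pyridin-3-yl)carbonyl on an amine nitrogen. Among the compounds with values here, of the measured steps, the one to compound 3 is the closer guide, since there too the aromatic ring left and a small group bearing a hydrogen-bond donor entered, with no step beyond the scatter; the step to compound 2 shows that a change at this position can also cost a modest amount. For compound 4 the expected outcome in this assay is therefore a small loss at most, a 1.6-fold higher number from compound 1 to compound 4 (0.20 log units; within the scatter). The estimate for compound 4 is 25 nM, within a range from 8 nM to 80 nM.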

Compound 4, half-maximal inhibitory concentration: 7.94 nM
For compound 4 the middle estimate is 3.1-fold (0.50 log units) above the measured one; measured number outside the range, below it.
By their numbers in this assay, from the lowest: compounds 4, 1, 3 and 2 (each within the scatter of the next, the first and the last beyond it).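

In this assay the sulfamoyl group, with no ring and 4 heavy atoms against 8, stands level with the (pyridin-3-yl)carbonyl group at a 2.0-fold lower number from compound 1 to compound 4 (0.30 log units; within the scatter) and so shows that neither the aromatic ring nor a carbonyl on this amine nitrogen is needed for a number in this low range. Within the data shown here, it also separates two groups that the earlier compounds could not, giving a 2.5-fold lower number from compound 3 to compound 4 (0.40 log units; beyond the scatter) and then a 5.0-fold lower number from compound 2 to compound 4 (0.70 log units; beyond the scatter) as the widest step in the set. No evidence is available to explain these differences.

The compounds shown leave open whether a methylsulfonyl group on the same amine nitrogen would hold this level, which would test the amino part of sulfamoyl. From the compounds shown here alone, a longer chain carrying the sulfamoylamino group also remains untested here.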